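Ester to acid on a shared coumarin-linked dithiolane amide core

The source may report more compounds than this note shows. Statements on the series, on what has been measured and on what is new or still open speak of the compounds shown alone.

Measured compounds in a functional assay on PC-12 cells (Rattus norvegicus) for cytotoxicity, read by MTT assay, with stated times of 3 h and 2 h, tested at 50 uM; a higher number here means a stronger effect of the compound at the concentration tested, a lower number a weaker effect:
compound 1 `O=C(CCCCC1CCSS1)NCc1cn(CCCOc2ccc3ccc(=O)oc3c2)nn1` gives 43.5%
compound 2 `CC(=O)c1cc2ccc(OCCCn3cc(CNC(=O)CCCCC4CCSS4)nn3)cc2oc1=O` gives 40.7%
compound 3 `CCOC(=O)c1cc2ccc(OCCCn3cc(CNC(=O)CCCCC4CCSS4)nn3)cc2oc1=O` gives 49.2%

The three numbers sit close together. In this assay compound 3 gives the largest of them, yet its separation from the others stays within the scatter: a number 5.7 percentage points higher from compound 1 to compound 3 (within the scatter) and a number 8.5 percentage points higher from compound 2 to compound 3 (within the scatter). The acetyl step, a number 2.8 percentage points lower from compound 1 to compound 2 (within the scatter), is likewise within the scatter. None of these three substituents on the aromatic carbon moved the read-out beyond what repeated measurements would give.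

Compound 4 `O=C(CCCCC1CCSS1)NCc1cn(CCCOc2ccc3cc(C(=O)O)c(=O)oc3c2)nn1` is not yet measured. It differs from compound 3 by hydrogen in place of ethyl on an oxygen next to a carbonyl group. Among the compounds with values here, no measured step replaces an ester by an acid, so none bears directly on this change. The nearest is the step from a methyl to an ethoxy on the carbonyl carbon, a number 8.5 percentage points higher from compound 2 to compound 3 (within the scatter), which was within the scatter, as was the step that introduced the ethoxycarbonyl, a number 5.7 percentage points higher from compound 1 to compound 3 (within the scatter). A step of no more than the scatter is therefore expected, a number 4.2 percentage points lower from compound 3 to compound 4 (within the scatter). Compound 4 is estimated at 45%, with a range from 30% to 60%.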

Compound 4, a percentage reported as activity, at one concentration (the size of the read-out at that concentration, not a potency): 73.5%
Beside the measured number, compound 4's estimate is 28.5 percentage points below it; the whole stated range lies below it.
By their numbers in this assay, from the lowest: compounds 2, 1 and 3 (each within the scatter of the next); then compound 4.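

In this assay, within the data shown here, replacing ethyl with hydrogen on the oxygen next to a carbonyl group gives the first step that passes the scatter (a number 24.3 percentage points higher from compound 3 to compound 4 (beyond the scatter)), so this position is not as indifferent as the earlier compounds suggested. The carboxy compound also stands apart from the other two, with hydroxy in place of methyl on the carbonyl carbon (a number 32.8 percentage points higher from compound 2 to compound 4 (beyond the scatter)) and with the carboxy group newly added to the shared core (a number 30 percentage points higher from compound 1 to compound 4 (beyond the scatter)), while compounds 1, 2 and 3 remain within the scatter of one another. Nothing available explains the difference between the ester and the acid.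

A primary amide or a tetrazole in place of the carboxy group would test whether this read-out is specific to the carboxylic acid. The compounds shown also leave open how the read-out of compound 4 behaves at other concentrations.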